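A para-substituent swap on a benzylamide scaffold

The source may report more compounds than this note shows. Statements on the series, on what has been measured and on what is new or still open speak of the compounds shown alone.

Measured compounds:
compound 1 `CC(C)(C)c1ccc(C(=O)NCc2ccc(OC(F)(F)F)cc2)cc1` gives 160 nM
compound 2 `CC(C)(C)c1ccc(C(=O)NCc2ccc(S(N)(=O)=O)cc2)cc1` gives 1400 nM

Both compounds were tested in an assay on HeLa cells with Bile acid receptor (Homo sapiens) as the target, read by a luciferase reporter, with a stated time of 24 h; on this read-out higher numbers stand for an effect only at larger amounts of compound and lower numbers for an effect already at smaller amounts. Of the two numbers available, compound 2 stands highest: compound 1 sits a lower number away, and that gap lies beyond the usual scatter. For the measured compounds named here, only one step has been measured on this series, from a trifluoromethoxy group to a sulfamoyl group on the same aromatic carbon, giving an 8.8-fold higher number from compound 1 to compound 2 (0.94 log units; beyond the scatter).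

Compound 3 `CC(=O)c1ccc(CNC(=O)c2ccc(C(C)(C)C)cc2)cc1` has not yet been measured in this assay. It differs from compound 2 by acetyl in place of sulfamoyl on an aromatic carbon; the group sits on an aromatic carbon of a six-membered aromatic ring of carbon only, para to a large group. Going by the values given here, no measured step concerns an acetyl group directly, so the only guide is that the sulfamoyl-bearing compound 2 gave the higher number of the pair, with compound 1 showing that a different group at this position can give a markedly lower one. On that basis the estimated step is a 3.1-fold lower number from compound 2 to compound 3 (0.49 log units; beyond the scatter), a lower number for compound 3 but not necessarily as low as compound 1. Compound 3 is therefore expected at 450 nM, with a range from 150 nM to 1400 nM.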

Compound 3, half-maximal effective concentration: 100 nM
The estimate for compound 3 lay 4.5-fold (0.65 log units) above the measured number, and the stated range ends above it.
By their numbers in this assay, from the lowest: compounds 3 and 1 (each within the scatter of the next); then compound 2.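

Replacing sulfamoyl with acetyl on this aromatic carbon gives a 14-fold lower number from compound 2 to compound 3 (1.15 log units; beyond the scatter) in this assay, a large step that shows the higher number of compound 2 is not shared by every group with a carbonyl-like double bond at this place. Acetyl in place of trifluoromethoxy gives a 1.6-fold lower number from compound 1 to compound 3 (0.20 log units; within the scatter), a difference within the usual scatter, so compound 1 and compound 3 cannot be told apart even though their groups are built from quite different atoms, and among these three compounds only the sulfamoyl group of compound 2 stands apart. Nothing available here explains why sulfamoyl separates from the other two groups.

The three compounds leave open whether the single hydrogen-bond donor of sulfamoyl, which acetyl lacks, has anything to do with the gap, since the two groups also differ in their atoms and double bonds. From the compounds shown here alone, it also remains open whether an amine, a carboxylic acid or a longer chain ending in a ketone on this same aromatic carbon would fall with compound 2 or with compound 1 and compound 3.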